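This account rests on a few compounds, and the source may have more. Where it says the series, first, only, none or still open, it means among the compounds named here.

Measured compounds in an assay on isolated protein (Bos taurus) with 5-hydroxytryptamine receptor 1D (Homo sapiens) as the target; on this read-out lower numbers stand for stronger inhibition and higher numbers for weaker inhibition:
Compound 1, `c1ccc2c(c1)CCC(CNCCCNC1=NCCN1)O2`: 6.31 nM
Compound 2, `c1ccc2c(c1)CCC(CNCCCNc1cnccn1)O2`: 10 nM

For the measured compounds named here, compound 2 stands level with compound 1 on these two numbers, since the two values lie within the scatter of each other: the step of a 1.6-fold higher number from compound 1 to compound 2 (0.20 log units; within the scatter) was the only one taken before compound 3.

Compound 3, `CC(C)/N=C(\N)NNCCCNCC1CCc2ccccc2O1`, arises from compound 2 by a group of 7 heavy atoms (4 carbon, 3 nitrogen; no ring) in place of a group of 6 heavy atoms (4 carbon, 2 nitrogen; one six-membered aromatic ring with 2 hetero atoms), on an amine nitrogen. Going by the values given here, the single measured step that bears on it is the exchange of one ring for another at the same amine nitrogen, a 1.6-fold higher number from compound 1 to compound 2 (0.20 log units; within the scatter), which changed nothing beyond the scatter. The move to compound 3 goes further, replacing a ring with a group that has none, so that step covers it only in part. The account therefore expects, for compound 3 in this assay, a step of a 1.5-fold higher number from compound 2 to compound 3 (0.18 log units; within the scatter) that stays close to the scatter, with no strong direction. The estimate for compound 3 is 15 nM, with a range from 4 nM to 60 nM.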

Compound 3, half-maximal inhibitory concentration: 3.16 nM
The estimate for compound 3 lay 4.7-fold (0.68 log units) above the measured number, outside the stated range (below it).
By their numbers in this assay, from the lowest: compounds 3, 1 and 2 (each within the scatter of the next, the first and the last beyond it).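

In this assay, for the compounds shown here, an open group with no ring can replace pyrazin-2-yl on this amine nitrogen without any loss, and a 3.2-fold lower number from compound 2 to compound 3 (0.50 log units; beyond the scatter) is the first step at this position to go beyond the scatter, though only modestly. Set against the five-membered non-aromatic ring of compound 1, the same open group gives a 2.0-fold lower number from compound 1 to compound 3 (0.30 log units; within the scatter), so compound 1 and compound 3 stand level, and a ring at this position is shown to be dispensable for a number of this size. Nothing measured here accounts for the difference between pyrazin-2-yl and the open group.

As far as these compounds go, whether a plain primary amine or a urea on the same nitrogen would stand with compound 3 or with compound 2 remains open. So does the effect of a longer chain in place of the present one.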